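A few compounds are considered here, and "the series" means these few. Any claim that something is new, unique, unknown or untested is made for them only; others in the source may bear on it.

Values in a functional assay on MCF7 cells (Homo sapiens) for cytotoxicity, read by MTT assay, with a stated time of 72 h; on this read-out lower numbers stand for stronger inhibition and higher numbers for weaker inhibition:
compound 1 `Cc1c(C)c2c(c(C)c1OC(=O)CCC(=O)NC1CC(C)(C)N([O])C(C)(C)C1)CC[C@@](C)(CCC[C@H](C)CCC[C@H](C)CCCC(C)C)O2`: > 300000 nM (a limit)
compound 2 `CC1(C)CC(NC(=O)CCC(=O)O)CC(C)(C)N1[O]`: > 300000 nM (a limit)
compound 3 `Cc1c(C)c2c(c(C)c1OC(=O)CCC(=O)NC1CC(C)(C)N([O])C1(C)C)CC[C@@](C)(CCC[C@H](C)CCC[C@H](C)CCCC(C)C)O2`: 95000 nM

Among the compounds with values here, compound 3 holds the only true number in this set. The rest of the set stands at the limit of > 300000 nM in this assay, at which 2 of the 3 values shown sit.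

The next structure is compound 4 `Cc1c(C)c2c(c(C)c1OC(=O)CCC(=O)NCC1CC(C)(C)N([O])C1(C)C)CC[C@@](C)(CCC[C@H](C)CCC[C@H](C)CCCC(C)C)O2`. On the amide-type nitrogen, its change from compound 3 is a group of 11 heavy atoms (9 carbon, 1 nitrogen, 1 oxygen; one five-membered non-aromatic ring with 1 hetero atom) in place of a group of 10 heavy atoms (8 carbon, 1 nitrogen, 1 oxygen; one five-membered non-aromatic ring with 1 hetero atom), on an amide-type nitrogen. A five-membered non-aromatic ring with 1 hetero atom is present on both sides of this change.

Within the data shown here, one measured step bears on it, an at least 3.1-fold lower number from compound 1 to compound 3 (0.49 log units; beyond the scatter). In that step a six-membered non-aromatic ring with 1 hetero atom gave way to a five-membered one. Among the measured compounds shown here, the ring type stays the same in the new change, so the earlier step is only a loose guide, and no measured step keeps the ring while changing the group. The expectation therefore starts from compound 3 at 95000 nM, with no shift beyond the scatter expected in this assay. The expected step is a 1.2-fold higher number from compound 3 to compound 4 (0.06 log units; within the scatter). Compound 4 is estimated at 110000 nM. The expected range for compound 4 runs from 40000 nM to 300000 nM.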

Compound 4, half-maximal inhibitory concentration: 260000 nM
Beside the measured number, compound 4's estimate is 2.4-fold (0.37 log units) below it, and the stated range covers the measured number.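

In this assay, the group on the amide-type nitrogen affects the read-out even when the five-membered non-aromatic ring with 1 hetero atom is present on both sides, a point that the earlier step, which also changed the ring, could not show: the group of 11 heavy atoms in place of the group of 10 heavy atoms gives a 2.7-fold higher number from compound 3 to compound 4 (0.44 log units; beyond the scatter). The comparison with the six-membered ring, at equal heavy-atom count, gives an at least 1.1-fold lower number from compound 1 to compound 4 (0.06 log units; that floor lies within the scatter), so the floor of this step lies within the scatter and no order can be read from it, and the five-membered ring cannot be said to improve on the six-membered ring in this pair. Compound 1 is recorded only as a limit, as are other values in the set: the limit of > 300000 nM in this assay, at which 2 of the 4 values shown sit.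

From the compounds shown here alone, it remains open whether the step from compound 3 to compound 4 reflects a general dependence on the size of this group, since a single step fixes no trend. Also open, going by these compounds, is how a longer chain, an amine or a carboxylic acid on the amide-type nitrogen would read in this assay.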